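The source may hold more compounds than are shown below. What is called first, only, known or untested is meant among the compounds shown, and "the series" means these compounds.

In a functional assay on NCI-H1975 cells (Homo sapiens) for cytotoxicity, read by MTT assay, with a stated time of 72 h (on this read-out higher numbers stand for weaker inhibition and lower numbers for stronger inhibition), two compounds sharing the same core have been read so far. Compound 1 `c1ccc(Nc2ncc3nc(Nc4ccccc4)n(C4CCCC4)c3n2)cc1` gives > 10000 nM, which is a limit of the assay and not a number. For the measured compounds named here, compound 2 `CN1CCN(c2ccc(Nc3ncc4nc(Nc5cccc([N+](=O)[O-])c5)n(C5CCCC5)c4n3)cc2)CC1` gives 980 nM, the only actual number available in this assay. Compound 3 `CN1CCN(c2ccc(Nc3ncc4nc(Nc5ccc(Br)cc5)n(C5CCCC5)c4n3)cc2)CC1` comes next, and its difference from compound 2 is 4-bromophenyl in place of 3-nitrophenyl on a nitrogen on an aromatic ring, with the rest of the molecule unchanged. Going by the values given here, no measured step isolates this change, so the expectation stays close to compound 2 at 980 nM, with no shift beyond the usual scatter and wide uncertainty in either direction. The expected change is a 1.0-fold higher number from compound 2 to compound 3 (0.01 log units; within the scatter). For compound 3 the estimated half-maximal inhibitory concentration is 1000 nM, with an expected range from 300 nM to 4000 nM.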

Compound 3, half-maximal inhibitory concentration: 2090 nM
Compound 3: middle estimate off by 2.1-fold (0.32 log units), on the low side; low and high end bracket the measured number.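

In this assay, for the compounds shown here, replacing 3-nitrophenyl with 4-bromophenyl on a nitrogen on an aromatic ring gives the only readable step so far, a 2.1-fold higher number from compound 2 to compound 3 (0.33 log units; beyond the scatter), so the group at this position does affect the read-out, if only modestly. Compound 3, at 2090 nM, still gives an actual number. Compound 1 differs from the others in more than one place and its value remains a limit, so it gives no step: the limit of > 10000 nM in this assay, at which 1 of the 3 values shown sits.

Because this single step changes both the substituent and its place on the ring, the two cannot be told apart here. As far as these compounds go, it remains open how an amine, a carboxylic acid or a methoxy group on this phenyl ring would read.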